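Urea series: removing one trifluoromethyl from compound 3

This account rests on a few compounds, and the source may have more. Where it says the series, first, only, none or still open, it means among the compounds named here.

Three compounds of the series carry a number in a functional assay on NCI-H23 cells (Homo sapiens) for inhibition, read by sulforhodamine B assay, with a stated time of 48 h, tested at 10 uM; on this read-out lower numbers stand for a stronger effect and higher numbers for a weaker effect at the one concentration tested. Compound 1 `COc1cc(Cl)cc(-c2nn(-c3cccc(NC(=O)c4ccc(Cl)c(Cl)c4)c3)cc2-c2ccncc2)c1` is the one amide of the set and gives 75.3% in this assay. Compound 2 `O=C(Nc1cccc(-n2cc(-c3ccncc3)c(-c3cc(O)cc(Cl)c3)n2)c1)Nc1ccc(Cl)c(Cl)c1`, a urea with a hydroxy rather than a methoxy on its core, gives -20.5% in this assay. Compound 3 `COc1cc(Cl)cc(-c2nn(-c3cccc(NC(=O)Nc4cc(C(F)(F)F)cc(C(F)(F)F)c4)c3)cc2-c2ccncc2)c1`, a urea with two trifluoromethyl groups on the terminal ring, gives -6.14% in this assay, which places it second highest of the three numbers: compound 2 is nearest, below it by a gap beyond the scatter, and compound 1 is furthest, above it by a large gap beyond the scatter.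

Compound 4 `COc1cc(Cl)cc(-c2nn(-c3cccc(NC(=O)Nc4cccc(C(F)(F)F)c4)c3)cc2-c2ccncc2)c1` has not been measured in this assay. It differs from compound 3 in one place: hydrogen in place of trifluoromethyl on an aromatic carbon. Among the measured compounds shown here, no step between measured compounds of the same kind is known, so the size of this change has to be judged from the series alone. Both ureas, compound 2 and compound 3, sit well below the amide compound 1, and the loss of a single trifluoromethyl is not expected to move compound 4 out of that low region. The step from compound 3 to compound 4 is estimated as a number 10.1 percentage points higher from compound 3 to compound 4 (beyond the scatter), a small shift upward that stays within the scatter. Compound 4 is therefore expected to give 4% in this assay, with a range from -25% to 35%.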

Compound 4, a percentage reported as activity, at one concentration (the size of the read-out at that concentration, not a potency): -5.1%
For compound 4 the middle estimate is 9.1 percentage points above the measured one; low and high end bracket the measured number.
By their numbers in this assay, from the lowest: compound 2; then compounds 3 and 4 (each within the scatter of the next); then compound 1.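

In this assay the step from removing one trifluoromethyl is a number 1 percentage points higher from compound 3 to compound 4 (within the scatter), so on this aromatic carbon of the terminal ring hydrogen and trifluoromethyl cannot be told apart at the one concentration tested, and a single trifluoromethyl on that ring is enough to keep the read-out of the urea in the range of compound 3. Among the compounds shown here, this is the first step that can be read at one place, and it sets a second one beside it: (3-(trifluoromethyl)phenyl)amino in place of 3,4-dichlorophenyl on the carbonyl carbon gives a number 80.4 percentage points lower from compound 1 to compound 4 (beyond the scatter), a step far larger than the one at the trifluoromethyl place. Nothing at hand gives a reason for either step.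

The large step joins the change from amide to urea with the change of ring substituents, so the compounds shown do not separate the share of each. Also open, as far as these compounds go, is how the read-out responds to a group such as an amine or a carboxylic acid on this aromatic carbon, and to hydroxy in place of methoxy on the core of compound 4.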